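From ethyl to oxolan-3-yl: a step beyond a limit

The source may report more compounds than this note shows. Statements on the series, on what has been measured and on what is new or still open speak of the compounds shown alone.

Compound 1 `Cc1cc(C(=O)NCc2ccccn2)nn1Cc1cc(Cl)ccc1OCc1ccccc1` gives > 3.7 (a limit)
Compound 2 `CCOC(=O)Nc1cc(C)n(Cc2cc(Cl)ccc2OCc2ccccc2)n1` gives > 3.7 (a limit)

In a physicochemical assay for lipophilicity, at pH 7.4 (a lower number here means a more polar compound, a higher number a more lipophilic compound), compound 2 gives > 3.7 as a limit and not a number. The same is true of compound 1, leaving the limit of > 3.7 in this assay, at which 2 of the 2 values shown sit, as the whole picture so far. Compound 3 (`Cc1cc(NC(=O)O[C@H]2CCOC2)nn1Cc1cc(Cl)ccc1OCc1ccccc1`) carries one change (oxolan-3-yl in place of ethyl on an oxygen next to a carbonyl group) that brings in a five-membered non-aromatic ring with a hetero atom. Going by the values given here, the only measured step that the two limits leave unreadable from compound 1 to compound 2 cannot be read, so no measured size guides the estimate. With that hydrogen-bond acceptor entering, a small downward move in this assay is expected, estimated as a step that the limit leaves unreadable from compound 2 to compound 3 overall. Compound 3 is expected at 4.1 within a range of 3.6 to 4.7 and may again return only a limit.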

Compound 3, distribution coefficient: 2.7
For compound 3 the middle estimate is 1.40 log units above the measured one; measured number below the stated range.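

In this assay, oxolan-3-yl in place of ethyl on an oxygen next to a carbonyl group gives a number at least 1.00 log units lower from compound 2 to compound 3 (beyond the scatter), and the larger swap gives a number at least 1.00 log units lower from compound 1 to compound 3 (beyond the scatter). This shows that the group on this oxygen can shift the reading, and compound 3 gives an actual number, 2.7. Compound 1 and compound 2 each give only a limit, so the step between them cannot be read: the limit of > 3.7 in this assay, at which 2 of the 3 values shown sit.

The compounds shown do not separate the ring from its oxygen, which cyclopentyl or a longer chain on that oxygen could address. From the compounds shown here alone, the mirror-image form of oxolan-3-yl also stays open.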